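The compounds below may be only part of what the source reports. "The series", "measured", "known", "first", "only" and "open" are said of these compounds alone.

Compound 1 `Cc1ccccc1-n1cc(-c2ccc(/C=C3\C(=O)Nc4ccccc43)cc2)nn1` gives 14700 nM in an ADME assay on HUVEC cells (Homo sapiens) for inhibition, read by CCK-8 assay, with a stated time of 24 h, in the presence of a further agent that is not named here; a lower number here means a stronger inhibitor, a higher number a weaker inhibitor; of the two numbers recorded, it lies within the scatter of compound 2 `O=C1Nc2ccccc2/C1=C/c1ccc(-c2cn(-c3ccccc3F)nn2)cc1`, which gives 19300 nM. Among the measured compounds shown here, the one measured step, a 1.3-fold higher number from compound 1 to compound 2 (0.12 log units; within the scatter), put fluoro in place of methyl on an aromatic carbon and stayed within the scatter. Compound 3 `O=C1Nc2ccccc2/C1=C/c1ccc(-c2cn(-c3ccc(F)cc3)nn2)cc1` differs from compound 1 by 4-fluorophenyl in place of 2-methylphenyl on an aromatic nitrogen. Because the related change a 1.3-fold higher number from compound 1 to compound 2 (0.12 log units; within the scatter) moved nothing beyond the scatter, compound 3 is expected to show no step beyond the scatter either, a 1.2-fold higher number from compound 1 to compound 3 (0.06 log units; within the scatter). Compound 3 is therefore estimated at 17000 nM, with a range from 8000 nM to 36000 nM.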

Compound 3, half-maximal inhibitory concentration: 14700 nM
The estimate for compound 3 lay 1.2-fold (0.06 log units) above the measured number; the measured number falls inside the stated range.
By their numbers in this assay, from the lowest: compounds 1, 3 and 2 (each within the scatter of the next).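

On the aromatic nitrogen of the five-membered ring, 4-fluorophenyl in place of 2-methylphenyl gives no change at the digits printed from compound 1 to compound 3 (within the scatter) and 4-fluorophenyl in place of 2-fluorophenyl gives a 1.3-fold lower number from compound 2 to compound 3 (0.12 log units; within the scatter) in this series. In this assay the 2-methylphenyl, 2-fluorophenyl and 4-fluorophenyl compounds therefore all lie within the scatter of one another. No supporting measurement bears on this result. On these data alone, it remains open whether a carboxylic acid or an amine on this phenyl ring, or a longer chain in its place on the nitrogen, would move the number beyond the scatter.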